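The source may report more compounds than this note shows. Statements on the series, on what has been measured and on what is new or still open speak of the compounds shown alone.

Compound 1 `CC(CC(=O)O)CC(=O)c1c(CCCCCCc2ccccc2)n(C)c2ccc(Cl)cc12` is a racemic acid whose side chain ends in a benzyl group six bonds removed from the aromatic core. In a functional assay for antagonist activity at Oxoeicosanoid receptor 1 (Homo sapiens), read by fluorescence and calcium flux, with stated times of 2 min and 1 min (on this read-out higher numbers stand for weaker inhibition and lower numbers for stronger inhibition), compound 1 gives 0.28 nM, the second highest of the three numbers recorded. Its single enantiomer, compound 2 `C[C@H](CC(=O)O)CC(=O)c1c(CCCCCCc2ccccc2)n(C)c2ccc(Cl)cc12`, gives 0.12 nM in this assay, and the step of a 2.3-fold lower number from compound 1 to compound 2 (0.37 log units; beyond the scatter) is accounted for by the fact that one of compounds 1 and 2 is drawn with a defined configuration and the other without, at the place where they differ. Compound 3 `CC(CC(=O)O)CC(=O)n1c(CCCc2ccccc2)cc2ccc(Cl)cc21`, which carries a different core and a shorter chain, gives 210 nM in this assay, far weaker than compound 1 and compound 2.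

Compound 4 `CC(CC(=O)O)CC(=O)c1c(CCCCCc2ccccc2)n(C)c2ccc(Cl)cc12` differs from compound 1 by one change: phenyl in place of benzyl on a saturated chain carbon, five bonds along the chain from an aromatic carbon. Among the compounds with values here, none of the measured steps touches the length of this chain; the only step recorded within the shared core concerns the stereocentre, and compound 3 changes too much at once to guide a one-carbon shortening. Compound 4 is therefore expected to stay close to compound 1, with any step a 1.8-fold higher number from compound 1 to compound 4 (0.25 log units; within the scatter) likely small and possibly within the scatter, though a modest loss cannot be excluded. The estimate for compound 4 in this assay is 0.5 nM, with a range from 0.15 nM to 2.5 nM.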

Compound 4, half-maximal inhibitory concentration: 11 nM
Compound 4: the middle estimate sits 22-fold (1.34 log units) below what was measured, outside the stated range (above it).
By their numbers in this assay, from the lowest: compound 2; then compound 1; then compound 4; then compound 3.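

Within the data shown here, replacing benzyl with phenyl on a saturated chain carbon, five bonds along the chain from an aromatic carbon, is the first comparable change that touches the chain itself, and in this assay it gives a 39-fold higher number from compound 1 to compound 4 (1.59 log units; beyond the scatter) and so is far larger than the stereocentre step, which is a 2.3-fold lower number from compound 1 to compound 2 (0.37 log units; beyond the scatter) in the same assay. This position therefore tolerates little change: the step is large even though the leaving and entering groups each hold one six-membered aromatic ring of carbon only, with no hydrogen-bond donors or acceptors and no net charge. The information available on these compounds concerns only the stereocentre and offers no explanation for this loss.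

The compounds shown leave open whether a longer chain would match or improve on compound 1, and whether a 4-phenylbutyl chain on the same core would lose still more. They also leave open whether a chain holding an ether oxygen or an amine would be accepted at this place, and whether the single enantiomer would respond to the shorter chain as the racemate does.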